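This account rests on a few compounds, and the source may have more. Where it says the series, first, only, none or still open, it means among the compounds named here.

Of the compounds shown here, two have been measured in a functional assay on MCF7 cells (Homo sapiens) for inhibition, read by MTT assay; a lower number here means a stronger inhibitor, a higher number a weaker inhibitor. Compound 1 `O=C(CN1CCN(c2ccccc2F)CC1)Nc1ccc(C(=O)/C=C/c2cn(Cc3ccc(Br)cc3)nn2)cc1` gives 11300 nM in this assay. Compound 2 `CCCCCCCCn1cc(/C=C/C(=O)c2ccc(NC(=O)CN3CCN(c4ccc([N+](=O)[O-])cc4)CC3)cc2)nn1` gives 49100 nM in this assay, the higher of the two numbers, and the gap to compound 1 is beyond the usual scatter, so compound 2 is the weaker inhibitor of the pair.

Compound 3 `O=C(CN1CCN(c2ccc([N+](=O)[O-])cc2)CC1)Nc1ccc(C(=O)/C=C/c2cn(Cc3ccc(Br)cc3)nn2)cc1` has not yet been measured. It differs from compound 2 in one place: 4-bromophenyl in place of heptyl on a saturated chain carbon bound to an aromatic nitrogen. Cut one bond further out, the same change reads octyl to 4-bromobenzyl, and the 4-bromobenzyl group that enters is the one already present in compound 1. Compound 3 therefore sits between the two measured compounds, carrying the nitrophenyl group of compound 2 together with the 4-bromobenzyl group of compound 1.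

Within the data shown here, with no measured step of this exact kind to lean on, the expectation is a move towards a lower number, beyond the scatter, because compound 1 gives 11300 nM while carrying that same 4-bromobenzyl group. The estimated step from compound 2 to compound 3 is a 3.1-fold lower number from compound 2 to compound 3 (0.49 log units; beyond the scatter). Compound 3 is thus estimated at 16000 nM in this assay, within a range from 6000 nM to 42000 nM.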

Compound 3, half-maximal inhibitory concentration: 31600 nM
The estimate for compound 3 lay 2.0-fold (0.30 log units) below the measured number; low and high end bracket the measured number.
By their numbers in this assay, from the lowest: compound 1; then compounds 3 and 2 (each within the scatter of the next).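

In this assay, exchanging octyl for 4-bromobenzyl, with the 4-nitrophenyl group held fixed, gives a 1.6-fold lower number from compound 2 to compound 3 (0.19 log units; within the scatter). A long open chain and a bromine-bearing aromatic ring at this place are therefore not told apart by this read-out, at least while the 4-nitrophenyl group is present. Among these compounds, with 4-bromobenzyl held fixed instead, the other exchange, 4-nitrophenyl in place of 2-fluorophenyl on an amine nitrogen in a ring, gives a 2.8-fold higher number from compound 1 to compound 3 (0.45 log units; beyond the scatter), so of the two single changes now on record only this one moves the number beyond the scatter, and only modestly. Nothing shown here explains either result.

On these data alone, it remains open whether a plain benzyl group or a shorter chain such as butyl would also match octyl at the first place, and whether the 2-fluorophenyl group would give the same step with octyl present. At the second place, 2-nitrophenyl or 4-fluorophenyl would show whether the step follows the kind of group on the aromatic ring or where that group sits on it.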